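Chain extension on the sulfonamide substituent of compound 1

The source may hold more compounds than are shown below. What is called first, only, known or untested is meant among the compounds shown, and "the series" means these compounds.

Working notes on a short series of antiproliferative measurements. Compound 1, `CCC1C(=O)N(C)c2cnc(Nc3ccc(S(=O)(=O)NCCO)cc3)nc2N1c1ccn(C)n1`, was tested in a functional assay on NCI-H1975 cells (Homo sapiens) for antiproliferative activity, read by CCK-8 assay, with a stated time of 72 h (on this read-out higher numbers stand for weaker inhibition of growth and lower numbers for stronger inhibition of growth), and was reported as "not active" (no number reported), so no single number places it on the scale; it stands only as a compound without measurable growth inhibition at the concentrations examined. Within the data shown here, compound 2, `CC[C@@H]1C(=O)N(C)c2cnc(-n3ccc4cc(F)ccc43)nc2N1C1CCCC1`, shares the core but carries different substituents at two positions; in this assay compound 2 gives 46500 nM, a weak result, and since no single-point step links it to compound 1 the two values show only that both sit at the weak end.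

Compound 3, `CCC1C(=O)N(C)c2cnc(Nc3ccc(S(=O)(=O)NCCCO)cc3)nc2N1c1ccn(C)n1`, is the next member to be measured in this assay. It differs from compound 1 in one place: hydroxymethyl in place of hydroxy on a saturated chain carbon, two bonds along the chain from a sulfonamide nitrogen. This is a small change at the end of a chain, and with compound 1 giving "not active" (no number reported) there is no reason to expect a shift beyond the usual scatter in either direction. For compound 3 the expectation in this assay is therefore a weak value of about 50000 nM, estimated to fall between 15000 nM and 200000 nM, with a fair chance that only a limit is reported.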

Compound 3, concentration for 50% growth inhibition: 25800 nM
Compound 3: the middle estimate sits 1.9-fold (0.29 log units) above what was measured; low and high end bracket the measured number.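

Among these compounds, with compound 1 at "not active" (no number reported) and compound 3 at 25800 nM in this assay no step between the two can be read. The compounds shown leave open how far going from 2-hydroxyethyl to 3-hydroxypropyl on the sulfonamide nitrogen shifts growth inhibition. No measured evidence bears on this result.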